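Cytotoxicity notes: loss of the trifluoromethyl group

A few compounds are considered here, and "the series" means these few. Any claim that something is new, unique, unknown or untested is made for them only; others in the source may bear on it.

Measured compounds:
compound 1, `O=C(Nc1ccc(C(F)(F)F)cc1)c1cc(Cl)ccc1O`: 510 nM
compound 2, `N#Cc1ccc(NC(=O)c2ccc(C(F)(F)F)cc2O)cc1`: 1030 nM
compound 3, `O=C(Nc1ccc([N+](=O)[O-])cc1Cl)c1cc(F)ccc1O`: 280 nM

In a functional assay on HL-60 cells (Homo sapiens) for cytotoxicity, read by luminescence and CellTiter-Glo, with a stated time of 3 days (on this read-out lower numbers stand for stronger inhibition and higher numbers for weaker inhibition), compound 2 stands at the highest number of the three. Its nearest neighbour is compound 1, with a gap beyond the scatter, and compound 3 lies furthest from it, also beyond the scatter. Compound 4 `N#Cc1ccc(NC(=O)c2ccccc2O)cc1` differs from compound 2 by hydrogen in place of trifluoromethyl on an aromatic carbon. Among the measured compounds shown here, no measured pair shares this change, so any expectation rests on the three values alone, and each of those carries a halogen-bearing substituent on the hydroxy-bearing ring that compound 4 lacks. A step toward weaker inhibition, beyond the scatter but modest, is expected from compound 2 to compound 4, estimated as a 2.4-fold higher number from compound 2 to compound 4 (0.39 log units; beyond the scatter). Compound 4 is accordingly estimated at 2500 nM, with a range of 900 nM to 7000 nM.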

Compound 4, half-maximal inhibitory concentration: 4620 nM
Compound 4: the middle estimate sits 1.8-fold (0.27 log units) below what was measured; the range from low to high includes it.
By their numbers in this assay, from the lowest: compounds 3 and 1 (each within the scatter of the next); then compound 2; then compound 4.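

Hydrogen in place of trifluoromethyl, on an aromatic carbon meta to a hydroxy group, gives a step toward weaker inhibition, with a 4.5-fold higher number from compound 2 to compound 4 (0.65 log units; beyond the scatter) as the first comparison in this series that changes one place only. Trifluoromethyl at this position therefore counts toward the stronger number of compound 2, although the data offer no explanation for the step.

Going by these compounds, whether methyl, an amine or a carboxylic acid on this carbon would hold that number stays open. Also open, on these data alone, is whether loss of trifluoromethyl from compound 1 gives a like step.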